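This account rests on a few compounds, and the source may have more. Where it says the series, first, only, none or still open, it means among the compounds named here.

Compound 1 `CCCOc1cc([N+](=O)[O-])ccc1NS(C)(=O)=O`: 2510 nM
Compound 2 `CCCOc1cc([N+](=O)[O-])ccc1N(C)S(C)(=O)=O`: 760 nM

The two measured compounds share one core and differ at a single place. In an assay on SK-BR-3 cells for inhibition of Aromatase (Homo sapiens) (a lower number here means a stronger inhibitor, a higher number a weaker inhibitor), compound 1 gives 2510 nM, and compound 2 gives 760 nM. Among the compounds with values here, the step of a 3.3-fold lower number from compound 1 to compound 2 (0.52 log units; beyond the scatter) is the only measured step in this set, and it arises from methyl in place of hydrogen on a sulfonamide nitrogen. On these two numbers compound 2 stands lowest, with its nearest neighbour, compound 1, sitting beyond the scatter.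

Compound 3 `COc1cc([N+](=O)[O-])ccc1N(C)S(C)(=O)=O` keeps the methyl on the sulfonamide nitrogen and alters a different group: hydrogen in place of ethyl on a saturated chain carbon bound to an oxygen on an aromatic ring. Within the data shown here, no measured step touches this group, so the one known step, which concerns another part of the molecule, gives no guide to the direction or size of the coming change. Without such a guide, the expectation for this assay is a change of uncertain direction that may well stay within the scatter, so the range must be wide. Compound 3 is therefore estimated at 1000 nM, between 300 nM and 3500 nM. The step this estimate implies, a 1.3-fold higher number from compound 2 to compound 3 (0.12 log units; within the scatter), is expected to be small.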

Compound 3, half-maximal inhibitory concentration: > 25000 nM
Compound 3: a limit, no number; the forecaster's own chance of this, stated with the estimate: 5%; middle value at least 25-fold (1.39 log units) from the limit.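

Within the data shown here, until this result, only the sulfonamide nitrogen had been varied, and the chain on the oxygen had not been tested at all. In this assay, shortening that chain from propoxy to methoxy gives an at least 32-fold higher number from compound 2 to compound 3 (1.51 log units; beyond the scatter), a larger change than the one seen at the nitrogen, a 3.3-fold lower number from compound 1 to compound 2 (0.52 log units; beyond the scatter), so this position counts for at least as much as the nitrogen in this pair of compounds. Compound 3 gives > 25000 nM, which is a limit of the assay and not a number, so the step shows only how far the number has moved at the least, and its true size stays unknown: the limit of > 25000 nM in this assay, at which 1 of the 3 values shown sits.

The compounds shown cover only a propoxy and a methoxy group at this place, so it remains open how the number moves with an ethoxy or a butoxy group, and whether a still longer chain would lower it further than compound 2 does. On these data alone, it also remains open whether a chain ending in an amine or a hydroxyl group would keep the number of compound 2 or lose it as compound 3 does.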